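Replacing a methylpiperazine with a hydroxyl-bearing chain

The compounds below may be only part of what the source reports. "The series", "measured", "known", "first", "only" and "open" are said of these compounds alone.

Of the compounds shown here, three sharing one core have been measured in a functional assay on K562 cells (Homo sapiens) for antiproliferative activity, read by MTT assay, with a stated time of 48 h; a higher number here means a weaker inhibitor, a lower number a stronger inhibitor. Compound 1 `CN(C)CCn1c(N)c(-c2nc3ccccc3[nH]2)c2nc(C#N)c(C#N)nc21` gives 6340 nM, compound 2 `CN1CCN(CCn2c(N)c(-c3nc4ccccc4[nH]3)c3nc(C#N)c(C#N)nc32)CC1` gives 6550 nM, and compound 3 `CN1CCN(CCCn2c(N)c(-c3nc4ccccc4[nH]3)c3nc(C#N)c(C#N)nc32)CC1` gives 1260 nM. Compound 2 holds the highest number of the three, but it does not stand apart from compound 1: the data show a 1.0-fold higher number from compound 1 to compound 2 (0.01 log units; within the scatter). Only compound 3 lies clearly lower, with a 5.2-fold lower number from compound 2 to compound 3 (0.72 log units; beyond the scatter).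

Compound 4 `N#Cc1nc2c(-c3nc4ccccc4[nH]3)c(N)n(CCCO)c2nc1C#N` departs from compound 2 by hydroxymethyl in place of 4-methylpiperazin-1-yl on a saturated chain carbon, two bonds along the chain from an aromatic nitrogen. Hydroxymethyl stands in place of 4-methylpiperazin-1-yl on a saturated chain carbon, two bonds along the chain from an aromatic nitrogen. Within the data shown here, no measured step makes this exchange, so the evidence is indirect. The nearest guide is compound 3, which carries a methyl-linked group at that place and shows a 5.2-fold lower number from compound 2 to compound 3 (0.72 log units; beyond the scatter). A smaller move in the same direction is therefore expected, given the different group that enters. The expected step is a 2.2-fold lower number from compound 2 to compound 4 (0.34 log units; beyond the scatter). The estimate for compound 4 is 3000 nM, with an expected range of 800 nM to 11000 nM.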

Compound 4, half-maximal inhibitory concentration: > 50000 nM
Compound 4 gave a limit, no number; the forecaster's own chance of this, stated with the estimate: 10%; middle value at least 16-fold (1.22 log units) away from the limit.
By their numbers in this assay, from the lowest: compound 3; then compounds 1 and 2 (each within the scatter of the next). At a limit, above all of these: compound 4.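

In this assay compound 4 gives a limit, not a number: the limit of > 50000 nM in this assay, at which 1 of the 4 values shown sits. Hydroxymethyl in place of the amine-bearing ends gives an at least 7.8-fold higher number from compound 1 to compound 4 (0.89 log units; beyond the scatter) and an at least 7.6-fold higher number from compound 2 to compound 4 (0.88 log units; beyond the scatter), whereas the earlier exchanges at this place either stayed within the scatter or lowered the number. With hydroxy in place of 4-methylpiperazin-1-yl, three bonds along the chain from an aromatic nitrogen, the data show an at least 39-fold higher number from compound 3 to compound 4 (1.59 log units; beyond the scatter), so the gain seen with compound 3 does not carry over to a chain ending in hydroxy.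

The compounds shown leave open whether the rise follows the removal of the amine or the arrival of the hydroxyl. A methoxy or a morpholine at the end of the same chain would help separate the two, and a carboxylic acid there would show how far other end groups behave like hydroxy.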